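Swapping chloro for nitro on two related cores

This account rests on a few compounds, and the source may have more. Where it says the series, first, only, none or still open, it means among the compounds named here.

Of the compounds shown here, three have been measured in an ADME assay on Vero cells (Chlorocebus sabaeus) for cytotoxicity, read by resazurin assay, with a stated time of 72 h; on this read-out lower numbers stand for stronger inhibition and higher numbers for weaker inhibition. Compound 1 `COc1ccc(C(=O)CCN2CCN(c3ccc(Cl)cc3)CC2)cc1OC` gives 185000 nM. Compound 2 `COc1ccc(C(=O)CCN2CCN(c3ccc([N+](=O)[O-])cc3)CC2)cc1OC` differs from compound 1 in one place: nitro in place of chloro on an aromatic carbon. In this assay compound 2 gives 105000 nM. Within the data shown here, this change is the single step of a 1.8-fold lower number from compound 1 to compound 2 (0.25 log units; within the scatter). Compound 3 `O=C(CCN1CCN(c2ccc(Cl)cc2)CC1)c1ccc(F)c(F)c1` rests on a different core; how that core differs from the core of compound 1 is not broken down here. In this assay compound 3 gives 86200 nM, a value that sits within the scatter of compound 2 while lying lower than the number of compound 1.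

Compound 4 `O=C(CCN1CCN(c2ccc([N+](=O)[O-])cc2)CC1)c1ccc(F)c(F)c1` has not yet been measured. It carries the core of compound 3 with the same change that turned compound 1 into compound 2: nitro in place of chloro on an aromatic carbon. Since the place of the change is described in the same words for both pairs, this is the same change, made on a second core.

Among the measured compounds shown here, the only guide to its effect is the step from compound 1 to compound 2, which stayed within the scatter. On that basis the expected step in this assay is a 1.7-fold lower number from compound 3 to compound 4 (0.24 log units; within the scatter), beside the earlier one. Compound 4 is therefore estimated at 50000 nM, with a likely range from 25000 nM to 110000 nM. This expectation rests on a single earlier step, so it is a loose one.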

Compound 4, half-maximal inhibitory concentration: 122000 nM
For compound 4 the middle estimate is 2.4-fold (0.39 log units) below the measured one; the whole stated range lies below it.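

In this assay, putting nitro in place of chloro on the second core gives a 1.4-fold higher number from compound 3 to compound 4 (0.15 log units; within the scatter), so on this core the change from 4-chlorophenyl to 4-nitrophenyl leaves no reading that can be told apart from repeat-measurement noise. Set beside the same change on the first core, the result gives no ground for saying that the two cores respond differently: the same change on two cores in this assay, a 1.8-fold lower number (0.25 log units; within the scatter) from compound 1 to compound 2 and a 1.4-fold higher number (0.15 log units; within the scatter) from compound 3 to compound 4, 2.5-fold (0.40 log units) apart, within the scatter of two such steps. This shows that, in both pairs, the change stays small enough to be lost in the scatter, but it does not show that the change has exactly the same effect on every core, or that it has no effect at all, and two pairs are too few to establish a rule for the series.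

The compounds shown leave open whether a different group on the aromatic carbon that carries chloro or nitro here, such as an amine, a nitrile or a carboxylic acid, would produce a step beyond the scatter. They also leave open whether the same swap would stay as small on a third core, or on a compound with a longer chain leading to the carbonyl.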